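The source may hold more compounds than are shown below. What is called first, only, known or untested is meant among the compounds shown, and "the series" means these compounds.

Measured compounds:
`C(#Cc1ncnc2c1ncn2Cc1ccccc1)c1ccccc1` compound 1, 98%
`C=Cc1ncnc2c1ncn2Cc1ccccc1` compound 2, 100%
`C(=C/c1ncnc2c1ncn2C1CCOCC1)\c1ccccc1` compound 3, 66%

In a functional assay on K562 cells (Homo sapiens) for inhibition, read by thymidine incorporation, with a stated time of 48 h, tested at 10 ug/mL (on this read-out lower numbers stand for less inhibition and higher numbers for more inhibition at the one concentration tested (going by the name of the read-out)), compound 3 gives 66%, the lowest of the three numbers; compound 1 with 98% and compound 2 with 100% both lie beyond the scatter above it. Compound 4 `C(=C/c1ncnc2c1ncn2Cc1ccccc1)\c1ccccc1` differs from compound 3 in one place: benzyl in place of oxan-4-yl on an aromatic nitrogen. Among the compounds with values here, no measured step changes this group, so none bears on it directly; the only measured step, a number 2 percentage points higher from compound 1 to compound 2 (within the scatter), alters a different part of the shared core and lies within the scatter. Compound 1 and compound 2 both carry benzyl and both give high numbers, so an upward step is expected for compound 4, estimated as a number 24 percentage points higher from compound 3 to compound 4 (beyond the scatter). Compound 4 is therefore expected to give 90%, within a range of 72% to 100%.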

Compound 4, a percentage reported as inhibition, at one concentration (the size of the read-out at that concentration, not a potency): 93%
For compound 4 the middle estimate is 3 percentage points below the measured one; the range from low to high includes it.
By their numbers in this assay, from the lowest: compound 3; then compounds 4, 1 and 2 (each within the scatter of the next).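

In this assay the group on the aromatic nitrogen clearly matters: benzyl in place of oxan-4-yl gives a number 27 percentage points higher from compound 3 to compound 4 (beyond the scatter). The group on the aromatic carbon shows no such effect once benzyl is present, with 2-phenylethenyl in place of vinyl giving a number 7 percentage points lower from compound 2 to compound 4 (within the scatter) and in place of 2-phenylethynyl giving a number 5 percentage points lower from compound 1 to compound 4 (within the scatter). No measurement here explains these results.

As far as these compounds go, whether the aromatic ring of benzyl is needed remains open, since a plain methyl or a cyclohexyl on that nitrogen would test it. A single concentration also cannot show how potency differs among compounds near the top of the scale.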